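Chloro in Place of Hydrogen on a Weakly Cytotoxic Core

A few compounds are considered here, and "the series" means these few. Any claim that something is new, unique, unknown or untested is made for them only; others in the source may bear on it.

Measured compounds:
compound 1, `Cc1cc(O)c(C(=O)/C=C/c2ccc(Cl)cc2)c(-c2ccccc2)c1C(=O)/C=C/c1ccc(Cl)cc1`: 30000 nM
compound 2, `Cc1cc(O)c(C(=O)/C=C/c2ccc(OCc3ccccc3)cc2)c(-c2ccc(OCc3ccccc3)cc2)c1C(=O)/C=C/c1ccc(OCc2ccccc2)cc1`: "not active" (no number reported)

Among the measured compounds shown here, compound 1 is the only compound with a numerical result: in a functional assay on HeLa cells (Homo sapiens) for cytotoxicity, read by MTT assay, with a stated time of 24 h (on this read-out lower numbers stand for stronger inhibition and higher numbers for weaker inhibition), compound 1 gives 30000 nM, a weak effect. Compound 2 is reported in this assay as "not active" (no number reported), without a number. Compound 3, `Cc1cc(O)c(C(=O)/C=C/c2ccc(Cl)cc2)c(-c2ccc(Cl)cc2)c1C(=O)/C=C/c1ccc(Cl)cc1`, is still to be measured; it differs from compound 1 by chloro in place of hydrogen on an aromatic carbon. For the measured compounds named here, no step between measured compounds is available to set the scale, and the change is small, so the expected step is a 1.5-fold lower number from compound 1 to compound 3 (0.18 log units; within the scatter), within the usual scatter, with at most a slight gain. Compound 3 is therefore estimated at 20000 nM, between 7000 nM and 60000 nM.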

Compound 3, half-maximal inhibitory concentration: "not active" (no number reported)
Compound 3: no number reported, so the estimate cannot be set against anything.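

Among the compounds shown here, compound 3 is reported only as not active, without a number, so no step from compound 1 can be read. Left open is how far chloro in place of hydrogen shifts cytotoxicity on the shared core. No further data shown bear on this result.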